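A Single Double Bond, Drawn Two Ways

The source may hold more compounds than are shown below. What is called first, only, known or untested is meant among the compounds shown, and "the series" means these compounds.

In a functional assay on CCRF-CEM cells (Homo sapiens) for cytotoxicity (on this read-out higher numbers stand for weaker inhibition of growth and lower numbers for stronger inhibition of growth), compound 1 (`CCCCCCn1c(=O)oc2ccc(NCc3cc(O)ccc3O)cc2c1=O`) gives 270 nM and compound 2 (`Oc1ccc(O)c(CNc2ccc(O)c(/C=C\CCc3ccccc3)c2)c1`) gives 700 nM as the higher number of the pair. Compound 2 is therefore the weaker growth inhibitor of the two, by a gap beyond the scatter. Compound 3 (`Oc1ccc(O)c(CNc2ccc(O)c(/C=C/CCc3ccccc3)c2)c1`) has the same atoms and bonds as compound 2 and differs only in configuration as drawn (the two compounds have the same atoms and bonds and differ only in configuration as drawn: 1 of 1 stereo elements differ; a double bond is drawn Z in compound 2 and E in compound 3) with a double bond drawn Z in compound 2 and E in compound 3. Going by the values given here, no measured pair shows what such a change does, so in this assay no step beyond the scatter is expected. The step of a 1.2-fold lower number from compound 2 to compound 3 (0.07 log units; within the scatter) is expected to stay small, and its direction is uncertain. Compound 3 is estimated at 600 nM with an expected range of 200 nM to 1800 nM once measured.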

Compound 3, concentration for 50% growth inhibition: 1100 nM
Estimate against measurement, compound 3: 1.8-fold (0.26 log units) below; the range from low to high includes it.
By their numbers in this assay, from the lowest: compound 1; then compounds 2 and 3 (each within the scatter of the next).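

Going from Z to E at the double bond gives a 1.6-fold higher number from compound 2 to compound 3 (0.20 log units; within the scatter) in this assay. This first pair to isolate the change therefore shows that, on this chain, the drawn configuration has no effect that can be told apart from the spread of repeat measurements. The comparison rests on that single feature, since nothing else separates the two compounds: the fact that compounds 2 and 3 differ only in the configuration as drawn.

One pair cannot show whether the configuration would stay this unimportant on a longer chain, or on a chain carrying an amine or a carboxylic acid. The compounds shown also leave open whether the double bond itself matters, as a fully saturated chain would be needed to answer that.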